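A few compounds are considered here, and "the series" means these few. Any claim that something is new, unique, unknown or untested is made for them only; others in the source may bear on it.

In a functional assay on L1210 cells (Mus musculus) for antiproliferative activity (on this read-out lower numbers stand for stronger inhibition and higher numbers for weaker inhibition), compound 1 (`Oc1cccc2nccc(O)c12`) gives only a limit, > 40000 nM. Compound 2 (`COc1cc(O)c2c(O)ccnc2c1`) also gives only a limit, > 40000 nM. Compound 3 (`COc1cc(C(F)(F)F)cc2nccc(O)c12`) likewise stands at a limit, > 40000 nM. All three therefore share one reading: the limit of > 40000 nM in this assay, at which 3 of the 3 values shown sit. The next change leads to compound 4 (`Oc1ccnc2cc(C(F)(F)F)cc(O)c12`): hydrogen in place of methyl on an oxygen on an aromatic ring. This is hydrogen in place of methyl on an oxygen on an aromatic ring, or methoxy to hydroxy. Within the data shown here, the one measured step that bears on it also involves a methoxy, on an aromatic carbon, and it is a step that the two limits leave unreadable from compound 1 to compound 2. It offers no size to carry over, so no shift beyond the scatter is expected. The estimated step is a number no higher from compound 3 to compound 4 (the limit leaves the size open). For compound 4 the expected value is 40000 nM, with an estimated range of 15000 nM to 80000 nM.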

Compound 4, half-maximal inhibitory concentration: > 40000 nM
Compound 4 was reported as a limit; the forecaster's own chance of this, stated with the estimate: 80%; the middle value sits exactly at the limit.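

The steps from compound 1, compound 2 and compound 3 to compound 4 cannot be read, as all four compounds give only a limit: the limit of > 40000 nM in this assay, at which 4 of the 4 values shown sit.

The compounds shown leave open whether methoxy, hydroxy or trifluoromethyl changes the read-out in this assay at all.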